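Methoxy in place of tert-butyl on the benzyl ring of compound 1

The source may report more compounds than this note shows. Statements on the series, on what has been measured and on what is new or still open speak of the compounds shown alone.

Among the compounds with values here, compound 1 `CC(C)(C)c1ccc(Cn2cc(C#N)c3c(N)ncnc32)cc1` stands at the low end of the numbers measured so far in a functional assay on KB cells (Homo sapiens) for cytotoxicity (a higher number here means a weaker inhibitor, a lower number a stronger inhibitor), where compound 1 gives 3000 nM. Its nearest neighbour is compound 2 `CC(C)(C)c1ccc(Cn2cc(C(=N)S)c3c(N)ncnc32)cc1`, which in this assay gives 7000 nM; the step of a 2.3-fold higher number from compound 1 to compound 2 (0.37 log units; beyond the scatter) exchanges the nitrile for a thioimidate on the shared core. Furthest away is compound 3 `COCCOCn1cc(C(N)=S)c2c(N)ncnc21`, which carries a thioamide and a methoxyethoxymethyl group on the core nitrogen and in this assay gives 183000 nM, a markedly higher number than compound 1 on both counts.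

Compound 4 `COc1ccc(Cn2cc(C#N)c3c(N)ncnc32)cc1` differs from compound 1 only on the benzyl ring: methoxy in place of tert-butyl on an aromatic carbon. Within the data shown here, none of the measured steps touches this ring; the one single-point step known, from compound 1 to compound 2, changes the substituent on the core instead, and compound 3 differs from compound 1 in two places at once. Among the measured compounds shown here, there is therefore no direct precedent, and the expectation for this assay rests on the assumption that the benzyl substituent matters less than the core substituent, with a wide range to cover the uncertainty. For compound 4 the estimated number in this assay is 6000 nM, between 2000 nM and 20000 nM, which is expected to correspond to the step of a 2.0-fold higher number from compound 1 to compound 4 (0.30 log units; within the scatter).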

Compound 4, half-maximal inhibitory concentration: > 100000 nM
Compound 4 was reported as a limit; the forecaster's own chance of this, stated with the estimate: 5%; at least 16-fold (1.22 log units) between middle value and limit.
By their numbers in this assay, from the lowest: compound 1; then compound 2; then compound 3.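

In this assay, compound 4 stands at a limit of the assay, > 100000 nM, and not at a number. Within the data shown here, the change on the benzyl ring gives an at least 33-fold higher number from compound 1 to compound 4 (1.52 log units; beyond the scatter), so this position, which no earlier step touched, moves the number further than the one step read so far on the core, a 2.3-fold higher number from compound 1 to compound 2 (0.37 log units; beyond the scatter). The size of the benzyl step is a lower bound and not a measured gap, since only a limit is available for compound 4: the limit of > 100000 nM in this assay, at which 1 of the 4 values shown sits.

On these data alone, what remains open is whether the loss of activity follows the departure of tert-butyl or the arrival of methoxy; a plain hydrogen, an isopropyl or a cyclohexyl on the same aromatic carbon would separate the two readings. Also open is whether the thioimidate keeps its modest step with methoxy on the benzyl ring, as the compounds shown pair that core change only with tert-butyl.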